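A Bromo Analogue Follows a Chloro Compound at the Limit

The source may report more compounds than this note shows. Statements on the series, on what has been measured and on what is new or still open speak of the compounds shown alone.

Of the compounds shown here, three sharing one core have been tested in a functional assay on A549 cells (Homo sapiens) for antiproliferative activity, read by MTT assay, with a stated time of 12 h; on this read-out higher numbers stand for weaker inhibition and lower numbers for stronger inhibition. Compound 1 `COc1cc(OC)c2c(=O)cc(/C=C/c3ccc([N+](=O)[O-])cc3)oc2c1` gives 19700 nM, and compound 2 `COc1cc(OC)c2c(=O)cc(/C=C/c3ccc(OCC4CC4)cc3)oc2c1` gives 20900 nM. For compound 3 `COc1cc(OC)c2c(=O)cc(/C=C/c3ccc(Cl)cc3)oc2c1` this assay reports only a limit, > 40000 nM. Compound 3 thus sits at the limit of > 40000 nM in this assay, at which 1 of the 3 values shown sits, with no number of its own. The steps toward it read an at least 2.0-fold higher number from compound 1 to compound 3 (0.30 log units; that floor lies within the scatter) and an at least 1.9-fold higher number from compound 2 to compound 3 (0.28 log units; that floor lies within the scatter), while a 1.1-fold higher number from compound 1 to compound 2 (0.03 log units; within the scatter) separates the two compounds that carry numbers. Compound 4 `COc1cc(OC)c2c(=O)cc(/C=C/c3ccc(Br)cc3)oc2c1` differs from compound 3 by bromo in place of chloro on an aromatic carbon. For the measured compounds named here, no measured step swaps one halogen for another, so the only steps that bear on compound 4 are those leading into compound 3, each of them a floor that the scatter could still cover. On that footing compound 4 is expected to behave much like compound 3, and the step of a number no higher from compound 3 to compound 4 (the limit leaves the size open) is estimated to stay within the scatter, in no settled direction. Compound 4 is accordingly estimated at 40000 nM in this assay, within a range from 15000 nM to 90000 nM, with a fair chance that this assay again returns only a limit rather than a number.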

Compound 4, half-maximal inhibitory concentration: > 40000 nM
Compound 4 ended at the assay's limit; the forecaster's own chance of this, stated with the estimate: 55%; the middle value sits exactly at the limit.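

In this assay the change from 4-chlorophenyl to 4-bromophenyl yields no number for the second halogen either, and compound 4 now stands with compound 3 at the assay's limit: the limit of > 40000 nM in this assay, at which 2 of the 4 values shown sit.

Both results are limits, not numbers, and the step between compound 3 and compound 4 cannot be read, so nothing here ranks bromo against chloro on this aromatic carbon. The two halogen compounds now stand at the limit while the nitro and cyclopropylmethoxy compounds carry numbers, yet the steps toward compound 4 are only floors, an at least 2.0-fold higher number from compound 1 to compound 4 (0.30 log units; that floor lies within the scatter) and an at least 1.9-fold higher number from compound 2 to compound 4 (0.28 log units; that floor lies within the scatter), and neither floor separates compound 4 from those two beyond the scatter.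

On these data alone, it remains open how far past the limit either halogen compound lies, and thus whether the halogens really part from compound 1 and compound 2 at all. Also open, as far as these compounds go, is whether an amine, a carboxylic acid or a longer chain on this same aromatic carbon of the shared core would give a number clearly lower than those of compound 1 and compound 2.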